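The source may report more compounds than this note shows. Statements on the series, on what has been measured and on what is new or still open speak of the compounds shown alone.

Measured so far:
compound 1 `O=c1sn(-c2ccccc2)c(=O)n1Cc1ccccc1` — 2380 nM
compound 2 `COc1ccc(-n2sc(=O)n(C3CCCCC3)c2=O)cc1` — < 2000 nM
compound 3 `COc1ccc(-n2sc(=O)n(-c3ccc(OC)cc3)c2=O)cc1` — < 2000 nM

All three were tested in an ADME assay, in phosphate buffer, with a stated time of 30 min, tested at 1 mM, at a dose of 1 mM; on this read-out lower numbers stand for lower exposure and higher numbers for higher exposure at the dose given. Compound 1 gives a plain number. For compound 2 the assay reports only a limit, not a number. Compound 3 likewise stands at a limit of this assay, and (the limit of < 2000 nM in this assay, at which 2 of the 3 values shown sit). Compound 4 `COc1ccc(-n2sc(=O)n(-c3ccc(Cl)cc3)c2=O)cc1` has not yet been measured; it differs from compound 3 by chloro in place of methoxy on an aromatic carbon. Among the measured compounds shown here, no measured pair shows how such a change moves the maximal plasma concentration, so the expectation is a step of no size beyond the scatter, in neither direction. Compound 4 is expected to give about 2000 nM, with a range from 800 nM to 4500 nM. The implied step, a number no lower from compound 3 to compound 4 (the limit leaves the size open), is an estimate and not a measurement.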

Compound 4, maximal plasma concentration: < 2000 nM
Compound 4: only a limit was reported (the forecaster's own chance of this, stated with the estimate: 50%); the middle value lies on the limit itself.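

Among the compounds shown here, compound 4 reads as a limit, not a number, as do compound 2 and compound 3, so no step to compound 4 from either can be read: the limit of < 2000 nM in this assay, at which 3 of the 4 values shown sit. On these data alone, how chloro in place of methoxy moves the maximal plasma concentration stays open.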